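A few compounds are considered here, and "the series" means these few. Any claim that something is new, unique, unknown or untested is made for them only; others in the source may bear on it.

Compound 1, with the structure `Oc1cccc(-c2cc(-c3ccccc3)cc(-c3ccco3)n2)c1`, was examined in an assay on isolated protein for inhibition of DNA topoisomerase 1 (Homo sapiens), with a stated time of 30 min, tested at 100 uM (a lower number here means a weaker effect, a higher number a stronger effect of the compound at the concentration tested), where compound 1 gives 10.2%. Compound 2, `Oc1cccc(-c2cc(-c3ccccc3)cc(-c3ccncc3)n2)c1`, shares its core and differs by pyridin-4-yl in place of furan-2-yl on an aromatic carbon. In this assay compound 2 gives 70.4%, so that a number 60.2 percentage points higher from compound 1 to compound 2 (beyond the scatter).

Compound 3, `Oc1ccc(-c2cc(-c3ccccc3)nc(-c3ccco3)c2)cc1`, is built from the same atoms as compound 1 joined differently; the difference between the two cores is not broken down here. In this assay compound 3 gives 5%, which sits within the scatter of the value of compound 1 and far from that of compound 2.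

Compound 4, `Oc1ccc(-c2cc(-c3ccccc3)nc(-c3ccncc3)c2)cc1`, has not yet been measured. It differs from compound 3 by pyridin-4-yl in place of furan-2-yl on an aromatic carbon. Within the data shown here, this is the same kind of change as the one from compound 1 to compound 2, though not the same: in compound 4 the entering group stands meta to a 4-hydroxyphenyl group, whereas in compound 2 it stands meta to a 3-hydroxyphenyl group. Among the measured compounds shown here, because the single precedent, a number 60.2 percentage points higher from compound 1 to compound 2 (beyond the scatter), was large, a step of comparable direction is expected from compound 3 to compound 4, estimated as a number 50 percentage points higher from compound 3 to compound 4 (beyond the scatter) in this assay, while the unlike surroundings of the place leave room for a smaller move. On that basis compound 4 is expected to give an estimated 55% in this assay, most likely between 25% and 80%.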

Compound 4, a percentage reported as inhibition, at one concentration (the size of the read-out at that concentration, not a potency): 57.5%
For compound 4 the middle estimate is 2.5 percentage points below the measured one, and the stated range covers the measured number.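

In this assay, the exchange of furan-2-yl for pyridin-4-yl on the second core gives a number 52.5 percentage points higher from compound 3 to compound 4 (beyond the scatter), a large step in the same direction as the one seen on the first core. Within this small set, the change therefore carries over from the core of compound 1 to the core of compound 3 with its size preserved, and the different placing of the hydroxyphenyl and phenyl groups leaves no mark on the step that can be told from the scatter: the same change on two cores in this assay, a number 60.2 percentage points higher (beyond the scatter) from compound 1 to compound 2 and a number 52.5 percentage points higher (beyond the scatter) from compound 3 to compound 4, 7.7 percentage points apart, within the scatter of two such steps This rests on only two pairs, read at a single concentration, so it shows neither a difference in potency nor why the change matters, and it does not establish that the step would carry over to any core beyond these two.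

The compounds shown leave open whether a pyridin-3-yl or thiophen-2-yl group in the same place would match pyridin-4-yl or stay closer to furan-2-yl. They also leave open whether the step would survive if a methoxy group or an amine took the place of the hydroxyl group on the hydroxyphenyl ring.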